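Shrinking the ester: from nitrophenyl to methyl

This account rests on a few compounds, and the source may have more. Where it says the series, first, only, none or still open, it means among the compounds named here.

Measured compounds:
- compound 1 `O=C(OC1(C(=O)Nc2ccc([N+](=O)[O-])cc2)CCCCC1)c1ccc(Br)cc1`: 284 nM
- compound 2 `O=C(OC1(C(=O)Nc2ccc([N+](=O)[O-])cc2)CCCCC1)c1ccc([N+](=O)[O-])cc1`: 14.1 nM
- compound 3 `CCOC(=O)c1ccccc1C(=O)OC1(C(=O)Nc2ccc([N+](=O)[O-])cc2)CCCCC1`: 517 nM

Three compounds share a core and differ only in the acid that forms the ester. In a functional assay on HepG2 cells (Homo sapiens) for inhibition, read by MTT assay, with a stated time of 72 h (a higher number here means a weaker inhibitor, a lower number a stronger inhibitor), compound 2 gives 14.1 nM, the lowest of the three numbers, with compound 1 next and compound 3 furthest. Going by the values given here, the one single-point step recorded, a 20-fold lower number from compound 1 to compound 2 (1.30 log units; beyond the scatter), is large and shows that the nitro on the aryl ester carries much of the activity.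

Compound 4 `CC(=O)OC1(C(=O)Nc2ccc([N+](=O)[O-])cc2)CCCCC1` takes this further: methyl in place of 4-nitrophenyl on a carbonyl carbon. Among the compounds with values here, the whole aryl piece, nitro included, is gone, so the step from compound 1 to compound 2 bears on it only indirectly, and no measured pair describes an ester of this small size. Because compound 2 with its nitro gives 14.1 nM while compounds 1 and 3 lacking it sit far higher, removing the aryl is expected to cost at least as much, and compound 4 is estimated at 700 nM (range 150 nM to 3500 nM), an expected step of a 50-fold higher number from compound 2 to compound 4 (1.70 log units; beyond the scatter) toward a weaker inhibitor.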

Compound 4, half-maximal inhibitory concentration: 519 nM
Compound 4: middle estimate off by 1.3-fold (0.13 log units), on the high side, within the range that was stated.
By their numbers in this assay, from the lowest: compound 2; then compounds 1, 3 and 4 (each within the scatter of the next).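

In this assay, replacing 4-nitrophenyl with methyl on this carbonyl carbon gives a 37-fold higher number from compound 2 to compound 4 (1.57 log units; beyond the scatter) and so costs a great deal. Replacing 4-bromophenyl with methyl at the same place gives a 1.8-fold higher number from compound 1 to compound 4 (0.26 log units; within the scatter) and is within the scatter, so the presence of an aromatic ring alone does not set the number here: the ring bearing bromo reads the same as a lone methyl, and only the 4-nitrophenyl ester stands apart. No measurement shown explains why the nitro-bearing ring behaves differently.

Still open, from the compounds shown here alone, is whether a nitrile in place of the nitro group on the ring would keep the number as low as that of compound 2. Going by these compounds, it is also open whether a longer chain, such as propyl, in place of methyl would read any differently from compound 4.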